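Swapping the ester for a nitrile on the pendant phenyl

A few compounds are considered here, and "the series" means these few. Any claim that something is new, unique, unknown or untested is made for them only; others in the source may bear on it.

Measured compounds:
compound 1, `Cc1ccc2cnc(-c3ccccc3)nc2n1`, 2700 nM
compound 2, `COC(=O)c1ccc(-c2ncc3ccc(C)nc3n2)cc1`, > 30000 nM

Of the compounds shown here, two sharing one core have been measured in a functional assay on CHO cells for antagonist activity at metabotropic glutamate receptor 5 (Rattus norvegicus), read by FLIPR and calcium flux; a lower number here means a stronger inhibitor, a higher number a weaker inhibitor. Compound 1 carries an unsubstituted phenyl and gives 2700 nM. Compound 2 carries a methoxycarbonyl on that phenyl, and in this assay compound 2 gives > 30000 nM, which is a limit of the assay rather than a number. So compound 2 stands at the weak end of what has been seen, at the limit of > 30000 nM in this assay, at which 1 of the 2 values shown sits. Among the compounds with values here, the one measured step, an at least 11-fold higher number from compound 1 to compound 2 (1.04 log units; beyond the scatter), shows that adding the methoxycarbonyl cost a great deal.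

Compound 3, `Cc1ccc2cnc(-c3ccc(C#N)cc3)nc2n1`, differs from compound 2 by cyano in place of methoxycarbonyl on an aromatic carbon. Within the data shown here, no measured step covers this exchange directly; the only step bears on it indirectly, in that it shows the unsubstituted phenyl of compound 1 well ahead of the methoxycarbonyl of compound 2. On these data alone, whether the smaller cyano recovers part of that loss is unknown. Compound 3 is therefore expected to show a modest gain, an at least 2.5-fold lower number from compound 2 to compound 3 (0.39 log units; beyond the scatter), though it may again sit at the limit.

Compound 3 is estimated at 12000 nM, with a range of 3000 nM to 30000 nM.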

Compound 3, half-maximal inhibitory concentration: > 30000 nM
Compound 3 ended at the assay's limit; the forecaster's own chance of this, stated with the estimate: 40%; middle value at least 2.5-fold (0.39 log units) away from the limit.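

Putting a cyano where hydrogen stood, on the aromatic carbon para to a large group, gives an at least 11-fold higher number from compound 1 to compound 3 (1.04 log units; beyond the scatter) in this assay. The loss at this position is therefore not peculiar to the methoxycarbonyl: it returns with a different and smaller group, so at this carbon only the unsubstituted phenyl has so far given a readable value. Compound 2 and compound 3 both sit at the same limit of the assay, so the step between them cannot be read and nothing can be said about their order: the limit of > 30000 nM in this assay, at which 2 of the 3 values shown sit.

On these data alone, it remains open whether a small group such as fluorine or methyl, or an amine, on this carbon would keep a readable value close to that of compound 1, at 2700 nM. As far as these compounds go, it is also open whether the loss belongs to this position alone, or whether a cyano or a methoxycarbonyl placed elsewhere on the phenyl would cost as much.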